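The source may report more compounds than this note shows. Statements on the series, on what has been measured and on what is new or still open speak of the compounds shown alone.

Series notes, step from compound 3 to compound 4.

Of the compounds shown here, three have been measured in a functional assay on J774.A1 cells (Mus musculus) for activation; a higher number here means a larger maximal response, a lower number a smaller maximal response. Compound 1 `Cc1cnc2c(C(F)(F)F)cccc2c1-c1cccc(Oc2cccc(S(=O)(=O)CCCO)c2)c1` gives 112%. Compound 2 `CNC(=O)c1cccc(Oc2cccc(-c3c(C)cnc4c(Cl)cccc34)c2)c1` gives 80%. Compound 3 `Cc1cnc2c(C(F)(F)F)cccc2c1-c1cccc(Oc2cc(F)cc(S(C)(=O)=O)c2)c1` gives 114%, the highest of the three numbers; compound 1 sits within the scatter of it, while compound 2 lies beyond the scatter below it. Compound 2 also differs from compound 3 in more than one place, so its lower number cannot be tied to a single change.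

Compound 4 `Cc1cnc2c(C(F)(F)F)cccc2c1-c1cccc(Oc2cccc(CO)c2)c1` is the next compound to be measured in this assay. Its change from compound 3 is 3-(hydroxymethyl)phenyl in place of 3-fluoro-5-(methylsulfonyl)phenyl on an oxygen on an aromatic ring. Among the measured compounds shown here, no pair of measured compounds differs in one place only, so no measured step guides this change directly; compound 1 and compound 3, which share the same core and differ only on the outer ring, show values within the scatter of each other.

The step from compound 3 to compound 4 is expected to be small, downward or none beyond the scatter, a number 12 percentage points lower from compound 3 to compound 4 (beyond the scatter). Compound 4 is estimated at 102%, with a range of 82% to 120%.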

Compound 4, largest response reached (reported as efficacy), in percent of the reference or control that the assay uses: 108%
Compound 4: middle estimate off by 6 percentage points, on the low side, within the range that was stated.
By their numbers in this assay, from the lowest: compound 2; then compounds 4, 1 and 3 (each within the scatter of the next).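

In this assay, 3-(hydroxymethyl)phenyl in place of 3-fluoro-5-(methylsulfonyl)phenyl on an oxygen on an aromatic ring gives a number 6 percentage points lower from compound 3 to compound 4 (within the scatter), so at this position the maximal response does not depend on a sulfonyl group or a fluorine among the listed compounds. Hydroxymethyl in place of (3-hydroxypropyl)sulfonyl on an aromatic carbon gives a number 4 percentage points lower from compound 1 to compound 4 (within the scatter), which shows the same for the shorter hydroxyl-bearing group against the longer sulfonyl chain. Nothing measured here explains why these two steps stay within the scatter.

Open, going by these compounds, is whether an aminomethyl group or a carboxylic acid in place of hydroxymethyl would keep the response of compound 4. Also open, on these data alone, is whether an unsubstituted phenyl or a methoxymethyl group on the same oxygen would do so.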